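The source may report more compounds than this note shows. Statements on the series, on what has been measured and on what is new or still open speak of the compounds shown alone.

The measured compounds and their values in a functional assay on HEK293 cells for agonist activity at probable G-protein coupled receptor 27 (Homo sapiens), read by a luciferase reporter and beta-arrestin recruitment, with a stated time of 10 min; a lower number here means that less compound is needed, a higher number that more compound is needed for the effect:
compound 1, `Cc1cc(Cl)ccc1C(=O)Nc1ccc(S(=O)(=O)Nc2ccccc2)cc1`, 912 nM;
compound 2, `O=C(Nc1ccc(S(=O)(=O)Nc2ccccc2)cc1)c1ccc(Cl)cc1Cl`, 457 nM;
compound 3, `O=C(Nc1ccc(S(=O)(=O)Nc2ccccc2Cl)cc1)c1ccc(Cl)cc1Cl`, 1260 nM.

Compound 2 and compound 3 share a core that differs in one place: chloro in place of hydrogen on an aromatic carbon. That difference gives a 2.8-fold higher number from compound 2 to compound 3 (0.44 log units; beyond the scatter). The compound still to be measured is compound 4, `Cc1ccccc1NS(=O)(=O)c1ccc(NC(=O)c2ccc(Cl)cc2Cl)cc1`, which differs from compound 3 by methyl in place of chloro on an aromatic carbon. The same change occurs among the measured compounds between compound 2 and compound 1: methyl in place of chloro on an aromatic carbon, and there it gave a 2.0-fold higher number from compound 2 to compound 1 (0.30 log units; within the scatter). The two places are not identical word for word: in compound 2 the changed aromatic carbon is also meta to a chloro group, whereas in compound 3 it is not, so the change in compound 4 is the same kind of change rather than the same one. Resting on that earlier step, the step from compound 3 to compound 4 is expected to be a 1.4-fold higher number from compound 3 to compound 4 (0.15 log units; within the scatter). Compound 4 is therefore estimated at 1800 nM, within a range from 700 nM to 4500 nM.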

Compound 4, half-maximal effective concentration: 1230 nM
Estimate against measurement, compound 4: 1.5-fold (0.17 log units) above, within the range that was stated.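

In this assay, methyl in place of chloro gives a 1.0-fold lower number from compound 3 to compound 4 (0.01 log units; within the scatter), and set beside the same change on the other core, the two steps cannot be told apart: the same change on two cores in this assay, a 2.0-fold higher number (0.30 log units; within the scatter) from compound 2 to compound 1 and a 1.0-fold lower number (0.01 log units; within the scatter) from compound 3 to compound 4, 2.0-fold (0.31 log units) apart, within the scatter of two such steps. Methyl in place of hydrogen gives a 2.7-fold higher number from compound 2 to compound 4 (0.43 log units; beyond the scatter), a modest step much like a 2.8-fold higher number from compound 2 to compound 3 (0.44 log units; beyond the scatter), so in these three compounds either group at that carbon goes with a higher number than hydrogen. This does not show that the swap of chloro for methyl is harmless or carries over in general, since it rests on just two pairs of compounds and says only that no difference between these two cores can be seen, not that none exists.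

The compounds shown leave open whether other groups on that same aromatic carbon, such as methoxy, trifluoromethyl or an amine, would sit with chloro and methyl or with hydrogen. They also leave open whether the swap would behave the same way on a core carrying a carboxylic acid.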